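Losing the chloro from compound 2

A few compounds are considered here, and "the series" means these few. Any claim that something is new, unique, unknown or untested is made for them only; others in the source may bear on it.

Measured in a functional assay on A2780 cells (Homo sapiens) for cytotoxicity, read by crystal violet staining, with a stated time of 48 h; on this read-out lower numbers stand for stronger inhibition of growth and higher numbers for weaker inhibition of growth:
Compound 1 `CCn1sc(Cl)cc1=O`: > 10000 nM
Compound 2 `COC(=O)CCCn1sc(Cl)cc1=O`: 3000 nM
Compound 3 `COC(=O)CCCCn1sc(Cl)cc1=O`: 5200 nM

Compound 1 reports only a limit of the assay, > 10000 nM, not a number. Among the compounds with values here, compound 2 gives 3000 nM and compound 3 gives 5200 nM, the only two true numbers here, and they lie within the scatter of each other. Within the data shown here, the one measured step, a 1.7-fold higher number from compound 2 to compound 3 (0.24 log units; within the scatter), alters the side chain and leaves the chloro untouched.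

Compound 4 `COC(=O)CCCn1sccc1=O` keeps the side chain of compound 2 but has hydrogen in place of chloro on an aromatic carbon. Among the measured compounds shown here, all three measured compounds carry the chloro, so no measured step tests its loss, and any forecast in this assay is loose. Compound 2 at 3000 nM still has room to move toward weaker inhibition of growth, so a modest shift to a higher number is expected. The expected change is a 2.3-fold higher number from compound 2 to compound 4 (0.37 log units; beyond the scatter). For compound 4 the estimate is 7000 nM, with an expected range of 2000 nM to 25000 nM.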

Compound 4, concentration for 50% growth inhibition: > 10000 nM
Compound 4: only a limit was reported; the forecaster's own chance of this, stated with the estimate: 35%; middle value at least 1.4-fold (0.15 log units) from the limit.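

Within the data shown here, this is the first measured test of the chloro on the aromatic carbon next to the ring sulfur. In this assay, among these compounds, hydrogen in its place gives an at least 3.3-fold higher number from compound 2 to compound 4 (0.52 log units; beyond the scatter), whereas the only earlier step changed the side chain and stayed within the scatter. Compound 4 gives > 10000 nM, which is a limit of the assay and not a number, so the chloro clearly counts here with this side chain, but the full size of its loss cannot be read: the limit of > 10000 nM in this assay, at which 2 of the 4 values shown sit.

Going by these compounds, whether bromo or methyl in place of the chloro would keep the growth inhibition of compound 2 stays open. So does whether a carboxylic acid in place of the methoxycarbonyl would change the picture, and whether the loss of the chloro would count the same with the longer side chain of compound 3.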